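The source may report more compounds than this note shows. Statements on the series, on what has been measured and on what is new or still open speak of the compounds shown alone.

Compound 1, with the structure `Fc1ccc(C2CC(c3ccc(Cl)s3)=NN2c2nc(-c3ccc(C(F)(F)F)cc3)cs2)cc1`, was tested in an ADME assay on NIH3T3 cells (Mus musculus) for cytotoxicity, read by XTT assay, with a stated time of 24 h; a lower number here means a stronger inhibitor, a higher number a weaker inhibitor. In that assay compound 1 reached only the limit of the measurement, reported as > 500 ug/mL, so no number is known for it. Compound 2, with the structure `Cc1ccc(C2=NN(c3nc(-c4ccccc4)cs3)C(c3ccc(F)cc3)C2)s1`, also reached only a limit in this assay, reported as > 500 ug/mL. For the measured compounds named here, compound 1 thus stands at the limit of > 500 ug/mL in this assay, at which 2 of the 2 values shown sit, and nothing in the numbers so far separates it from compound 2. The unmeasured compound 3 has the structure `CS(=O)(=O)c1ccc(-c2csc(N3N=C(c4ccc(Cl)s4)CC3c3ccc(F)cc3)n2)cc1` and differs from compound 1 by methylsulfonyl in place of trifluoromethyl on an aromatic carbon. Going by the values given here, no step between measured compounds is available, so the expectation for a number no higher from compound 1 to compound 3 (the limit leaves the size open) is no change beyond the scatter. Compound 3 is therefore expected to give about 500 ug/mL in this assay, with a range from 200 ug/mL to 1000 ug/mL, most likely again as a limit.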

Compound 3, half-maximal inhibitory concentration: > 500 ug/mL
Compound 3: only a limit was reported; the forecaster's own chance of this, stated with the estimate: 80%; the middle value sits exactly at the limit.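

For the compounds shown here, compound 1 and compound 3 both reached only a limit in this assay so no step between them can be read: the limit of > 500 ug/mL in this assay, at which 3 of the 3 values shown sit.

The compounds shown leave open how weak each one truly is in this assay and whether swapping trifluoromethyl for methylsulfonyl changes anything there.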